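The source may report more compounds than this note shows. Statements on the series, on what has been measured and on what is new or still open speak of the compounds shown alone.

Among the measured compounds shown here, compound 1 `Nc1cccc(-c2cnc(C(=O)CCCCCCc3ccccc3)o2)c1` gives 19 nM in an assay (Rattus norvegicus) for inhibition of Fatty-acid amide hydrolase 1 (Homo sapiens) (on this read-out lower numbers stand for stronger inhibition and higher numbers for weaker inhibition), while compound 2 `O=C(CCCCCCc1ccccc1)c1ncc(C(=O)C(F)(F)F)o1` gives 4 nM, the lowest of the two numbers at hand; the only measured step, a 4.8-fold lower number from compound 1 to compound 2 (0.68 log units; beyond the scatter), came with (trifluoromethyl)carbonyl in place of 3-aminophenyl. Compound 3 `CSc1cnc(C(=O)CCCCCCc2ccccc2)o1` carries a further change at the same place: methylsulfanyl in place of (trifluoromethyl)carbonyl on an aromatic carbon. For the measured compounds named here, only that one step bears on it, and it shows that this position moves the number beyond the scatter. A weaker result is therefore expected, estimated as a 10-fold higher number from compound 2 to compound 3 (1.00 log units; beyond the scatter). For compound 3 the expected value is 40 nM, within 10 nM to 160 nM.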

Compound 3, inhibition constant: 25 nM
Compound 3: the middle estimate sits 1.6-fold (0.20 log units) above what was measured, and the stated range covers the measured number.
By their numbers in this assay, from the lowest: compound 2; then compounds 1 and 3 (each within the scatter of the next).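

With methylsulfanyl in place of (trifluoromethyl)carbonyl, this assay shows a 6.3-fold higher number from compound 2 to compound 3 (0.80 log units; beyond the scatter) on the same ring carbon. Methylsulfanyl and 3-aminophenyl, by contrast, give a 1.3-fold higher number from compound 1 to compound 3 (0.12 log units; within the scatter) at this place, so among these three groups only (trifluoromethyl)carbonyl stands apart. No measurement at hand accounts for this difference. On these data alone, it remains open whether the lower number of compound 2 follows from the carbonyl or from its trifluoromethyl part. An acetyl group or a carboxylic acid at this place would help separate the two.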